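From methyl to fluoro: the step to compound 3

This account rests on a few compounds, and the source may have more. Where it says the series, first, only, none or still open, it means among the compounds named here.

Compound 1 `Fc1ccc(-c2nnc(SCCCN3CCN(c4nc5ccccc5o4)CC3)o2)cc1` gives 52300 nM as measured
Compound 2 `Cc1ccc(-c2nnc(SCCCN3CCN(c4nc5ccccc5s4)CC3)o2)cc1` gives 107000 nM as measured

Both values come from a functional assay on MCF7 cells (Homo sapiens) for inhibition, read by MTT assay, with a stated time of 72 h (a higher number here means a weaker inhibitor, a lower number a stronger inhibitor), and are the only two measured so far. Compound 2 stands highest of the pair, and compound 1 lies just beyond the usual scatter under it. Compound 3 `Fc1ccc(-c2nnc(SCCCN3CCN(c4nc5ccccc5s4)CC3)o2)cc1` has not yet been measured. It departs from compound 2 in one place, fluoro in place of methyl on an aromatic carbon, counted as fluoro in place of methyl on an aromatic carbon and reading 4-methylphenyl to 4-fluorophenyl when cut one bond further out. Going by the values given here, no step between measured compounds shows what such an exchange does, so the expectation rests on little. Among the compounds with values here, since compound 1 at 52300 nM is the only lower number available, a modest move toward a lower number is expected in this assay and it may stay within the scatter. The expected step is a 1.5-fold lower number from compound 2 to compound 3 (0.18 log units; within the scatter) in this estimate. Compound 3 is expected at 70000 nM with an estimated range from 30000 nM to 150000 nM for now.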

Compound 3, half-maximal inhibitory concentration: 84100 nM
Beside the measured number, compound 3's estimate is 1.2-fold (0.08 log units) below it; low and high end bracket the measured number.
By their numbers in this assay, from the lowest: compounds 1, 3 and 2 (each within the scatter of the next, the first and the last beyond it).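

In this assay, going by these compounds alone, fluoro in place of methyl on an aromatic carbon, para to a large group, gives a 1.3-fold lower number from compound 2 to compound 3 (0.10 log units; within the scatter), the first reading of this exchange, and its size cannot be told apart from repeat measurement. Compound 3 also supplies the first one-place link to compound 1: 1,3-benzothiazol-2-yl in place of 1,3-benzoxazol-2-yl on an amine nitrogen in a ring gives a 1.6-fold higher number from compound 1 to compound 3 (0.21 log units; within the scatter), so this exchange likewise remains inside the scatter, and neither single exchange on its own shows a clear effect. Nothing given here explains these values.

The compounds shown leave open whether another group at this place on the phenyl ring, such as a methoxy group, a nitrile or an amine, would give a step beyond the scatter. They also leave open how the values would respond to changes elsewhere, such as a longer chain between the sulfur and the piperazine-bearing end of the molecule, or a carboxylic acid on the benzothiazole.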